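A second aryl exchange on the aromatic nitrogen

The source may hold more compounds than are shown below. What is called first, only, known or untested is meant among the compounds shown, and "the series" means these compounds.

Compound 1, `N#CC1=C(N)Oc2c(N)cc3nc4ccccc4nc3c2C12C(=O)N(Cc1cnnn1-c1cccc(Br)c1)c1ccccc12`, in a functional assay on MCF7 cells (Homo sapiens) for antiproliferative activity, read by MTT assay, with a stated time of 48 h (a higher number here means a weaker inhibitor, a lower number a stronger inhibitor), gives a limit, > 50000 nM. Compound 2, `COc1ccccc1-n1nncc1CN1C(=O)C2(C(C#N)=C(N)Oc3c(N)cc4nc5ccccc5nc4c32)c2ccccc21`, in this assay gives 28900 nM.

Within the data shown here, compound 2 holds the only number recorded in this assay; the other value recorded is a limit. The step of an at least 1.7-fold lower number from compound 1 to compound 2 (0.23 log units; that floor lies within the scatter) is bounded by the limit of > 50000 nM in this assay, at which 1 of the 2 values shown sits, and its floor lies within the scatter. Compound 3, `CCc1cccc(C)c1-n1nncc1CN1C(=O)C2(C(C#N)=C(N)Oc3c(N)cc4nc5ccccc5nc4c32)c2ccccc21`, differs from compound 2 in one place: 2-ethyl-6-methylphenyl in place of 2-methoxyphenyl on an aromatic nitrogen. Among the measured compounds shown here, the only measured step that bears on this change is an at least 1.7-fold lower number from compound 1 to compound 2 (0.23 log units; that floor lies within the scatter), an exchange of the aryl group on the same aromatic nitrogen; it sets no more than a floor within the scatter, so it gives no ground to expect a shift beyond the scatter in this assay for the present exchange either. Near compound 2, compound 3 is expected at 30000 nM, with a range from 12000 nM to 80000 nM. The expected step of a 1.0-fold higher number from compound 2 to compound 3 (0.02 log units; within the scatter) is estimated to lie within the scatter, with a real chance that only a limit is reported.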

Compound 3, half-maximal inhibitory concentration: > 50000 nM
Compound 3 ended at the assay's limit; the forecaster's own chance of this, stated with the estimate: 35%; middle value at least 1.6-fold (0.22 log units) away from the limit.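

The exchange of 2-methoxyphenyl for 2-ethyl-6-methylphenyl on the aromatic nitrogen brings an at least 1.7-fold higher number from compound 2 to compound 3 (0.23 log units; that floor lies within the scatter) in this assay, so this second aryl exchange, like the first, yields only a floor and no measured size. The entering group has no hydrogen-bond acceptor where the leaving group has one, yet the floor does not show whether this difference matters, and the step between compound 1 and compound 3 cannot be read, as both values are limits. Compound 2 thus remains the only one of the three compounds with a number rather than a limit, and the new result adds a second compound at the top of the measurable range: the limit of > 50000 nM in this assay, at which 2 of the 3 values shown sit.

Whether any exchange at this position moves the number beyond the scatter remains open, and so does the true size of all the steps shown. Also open, as far as these compounds go, is how the number would respond to an amine or a carboxylic acid on the phenyl ring, or to a longer chain such as hexyl in place of the aryl group on the aromatic nitrogen.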